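Acetyl for nitro on a biphenyl ester

A few compounds are considered here, and "the series" means these few. Any claim that something is new, unique, unknown or untested is made for them only; others in the source may bear on it.

Compound 1 `CCOC(=O)c1cccc(-c2ccc([N+](=O)[O-])cc2)c1`: 95000 nM
Compound 2 `CCOC(=O)c1cccc(-c2ccc(CN(C)C)o2)c1`: 190000 nM

Of the compounds shown here, two have been measured in an assay on COS-7 cells for inhibition of patatin-like phospholipase domain-containing protein 2 (Mus musculus); on this read-out higher numbers stand for weaker inhibition and lower numbers for stronger inhibition. Compound 1 gives 95000 nM in this assay, and compound 2 gives 190000 nM; the two values lie within the usual scatter of each other, so neither can be set apart from the other. Compound 3 `CCOC(=O)c1cccc(-c2ccc(C(C)=O)cc2)c1` has not been measured. It differs from compound 1 by acetyl in place of nitro on an aromatic carbon. Going by the values given here, no step between measured compounds of this kind is known. The step of a 1.3-fold higher number from compound 1 to compound 3 (0.10 log units; within the scatter) is expected to be small, not beyond the scatter in either direction. Compound 3 is therefore estimated at 120000 nM in this assay, with a range from 40000 nM to 400000 nM.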

Compound 3, half-maximal inhibitory concentration: 200000 nM
For compound 3 the middle estimate is 1.7-fold (0.22 log units) below the measured one; the range from low to high includes it.
By their numbers in this assay, from the lowest: compounds 1, 2 and 3 (each within the scatter of the next, the first and the last beyond it).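

In this assay, the aromatic carbon para to a large group proves sensitive to this exchange: acetyl in place of nitro gives a 2.1-fold higher number from compound 1 to compound 3 (0.32 log units; beyond the scatter), a modest step, but one that lies beyond the scatter. The two groups have the same count of heavy atoms, so a change that keeps this count can still shift the number. No measurement at hand gives a reason for the step. Going by these compounds, it remains open whether an amine or a carboxylic acid at this position would give a lower or a higher number than nitro, and whether replacing the ethyl ester of the shared core with an amide would shift the number at all.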